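Swapping Fluoro for Chloro in a Nitro-Bearing Series

The compounds below may be only part of what the source reports. "The series", "measured", "known", "first", "only" and "open" are said of these compounds alone.

In a functional assay on HSC-2 cells (Homo sapiens) for cytotoxicity, with a stated time of 24 h (a higher number here means that more compound is tolerated, a lower number that less compound is tolerated), the three measured compounds stand as follows:

Compound 1 `O=C1/C(=C/c2ccc(F)cc2)CCC/C1=C\c1ccccc1[N+](=O)[O-]` gives 2700 nM.
Compound 2 `O=C1/C(=C/c2ccc(Cl)cc2)CCC/C1=C\c1ccccc1[N+](=O)[O-]` gives 3700 nM.
Compound 3 `O=C1/C(=C/c2ccc(F)cc2)CCC/C1=C\c1cccc([N+](=O)[O-])c1` gives 2200 nM.

All three numbers sit close together, and none of the gaps between them goes beyond the usual scatter of repeated runs, so no ordering among them can be claimed. For the measured compounds named here, the one change that links two measured compounds directly is chloro in place of fluoro on an aromatic carbon, and it produced a 1.4-fold higher number from compound 1 to compound 2 (0.14 log units; within the scatter). Compound 3 shares its atoms with compound 1 but joins them differently; the difference between the two cores is not broken down here.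

Compound 4 `O=C1/C(=C/c2ccc(Cl)cc2)CCC/C1=C\c1cccc([N+](=O)[O-])c1` has not yet been measured. It differs from compound 3 by chloro in place of fluoro on an aromatic carbon, and the place of this change is the same, word for word, as in the pair already measured, so it is the same change made on the other core. Because the earlier instance gave a 1.4-fold higher number from compound 1 to compound 2 (0.14 log units; within the scatter), compound 4 is expected to move by a step of about a 1.4-fold higher number from compound 3 to compound 4 (0.13 log units; within the scatter) in this assay. On that basis compound 4 is estimated at 3000 nM, with a likely range from 1500 nM to 6000 nM, which overlaps what compound 3 already shows.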

Compound 4, half-maximal cytotoxic concentration: 2200 nM
For compound 4 the middle estimate is 1.4-fold (0.13 log units) above the measured one; the range from low to high includes it.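

On the core of compound 3, putting chloro in place of fluoro gave no change at the digits printed from compound 3 to compound 4 (within the scatter) in this assay. Set beside the earlier instance of this swap, the two steps cannot be told apart: the same change on two cores in this assay, a 1.4-fold higher number (0.14 log units; within the scatter) from compound 1 to compound 2 and no change at the digits printed (within the scatter) from compound 3 to compound 4, 1.4-fold (0.14 log units) apart, within the scatter of two such steps. For the compounds shown here, in these two pairs, then, the change carries from one core to the other without any readable shift, but both steps lie within the scatter, so this shows only that the swap leaves no clear mark on either core, and it does not show that a change with a large effect on one of these cores would carry over in the same way.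

The compounds shown hold only fluoro or chloro on this aromatic carbon, so it remains open what a larger or quite different group there, such as a methoxy group, an amine or a carboxylic acid, would do to the number on either core. Going by these compounds, it is also open whether fluoro and chloro would still read alike on a core that carries a nitrile or an amine in place of the nitro group, or in any other cell line.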